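From 4-nitrobenzyl to 3-(trifluoromethyl)benzyl: an expectation

The compounds below may be only part of what the source reports. "The series", "measured", "known", "first", "only" and "open" are said of these compounds alone.

Measured so far:
compound 1 `COC(=O)C1=CN(C)C(=O)[C@@H]2C(CN3CCN(Cc4ccc(C(F)(F)F)cc4)CC3)=CC[C@H]12`, 80.9%
compound 2 `COC(=O)C1=CN(C(C)C)C(=O)[C@@H]2C(CN3CCN(Cc4ccc([N+](=O)[O-])cc4)CC3)=CC[C@H]12`, 87.6%
compound 3 `COC(=O)C1=CNC(=O)[C@@H]2C(CO)=CC[C@H]12`, 79.3%

In a functional assay on Cortical neurone cells (Rattus norvegicus, strain Sprague-Dawley), read by MTT assay, with stated times of 24 h and 2 h, tested at 10 uM (a lower number here means a weaker effect, a higher number a stronger effect of the compound at the concentration tested), compound 2 gives 87.6%, the highest of the three numbers, yet compound 1 and compound 3 both lie within the usual scatter of it, so no order among the three can be claimed. Compound 4 `COC(=O)C1=CN(C(C)C)C(=O)[C@@H]2C(CN3CCN(Cc4cccc(C(F)(F)F)c4)CC3)=CC[C@H]12` is not yet measured. It differs from compound 2 by 3-(trifluoromethyl)phenyl in place of 4-nitrophenyl on a saturated chain carbon bound to an amine nitrogen in a ring. For the measured compounds named here, no step between measured compounds is available to size this change. As the three measured compounds, though differing widely, sit close together in this assay, no step beyond the scatter is expected for the change from compound 2 to compound 4. Compound 4 is therefore estimated at 84%, within 70% to 95%, meaning an expected step of a number 3.6 percentage points lower from compound 2 to compound 4 (within the scatter).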

Compound 4, a percentage reported as activity, at one concentration (the size of the read-out at that concentration, not a potency): 85.5%
Compound 4: the middle estimate sits 1.5 percentage points below what was measured; measured number inside the range.
By their numbers in this assay, from the lowest: compounds 3, 1, 4 and 2 (each within the scatter of the next).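

In this assay, 3-(trifluoromethyl)phenyl in place of 4-nitrophenyl, on a saturated chain carbon bound to an amine nitrogen in a ring, gives a number 2.1 percentage points lower from compound 2 to compound 4 (within the scatter). For the compounds shown here, this is the first step that can be sized at this place, and it shows that an aryl group with hydrogen-bond acceptors can give way to one with none without a change beyond the scatter. No supporting measurement bears on this result.

Group identity and ring position change together here, so their contributions cannot be separated. From the compounds shown here alone, whether an unsubstituted phenyl, or a phenyl carrying a carboxylic acid or an amine, would shift the number beyond the scatter remains open.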